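Methoxy in place of hydroxy on the chloroacetyl urea series

This account rests on a few compounds, and the source may have more. Where it says the series, first, only, none or still open, it means among the compounds named here.

The series is read in a functional assay on M21 cells (Homo sapiens) for antiproliferative activity, with a stated time of 48 h; on this read-out lower numbers stand for stronger inhibition and higher numbers for weaker inhibition. Compound 1 `CCCCC(OC)c1cccc(NC(=O)NCCCCl)c1` gives 51000 nM. Compound 2 `CCCCCc1cccc(NC(=O)NC(=O)CCl)c1` gives 3500 nM, and compound 3 `CCCCC(O)c1cccc(NC(=O)NC(=O)CCl)c1` gives 4600 nM. Within the data shown here, the only single-change step so far is the one a 1.3-fold higher number from compound 2 to compound 3 (0.12 log units; within the scatter), so the hydroxy on the chain carbon bound to the aromatic carbon leaves the number where it was. Compound 3 thus sits with the second highest number of the three, with compound 2 within the scatter of it and compound 1 well apart, but compound 1 also carries a different urea side chain, so its gap to compound 3 cannot be read as one change.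

Compound 4 `CCCCC(OC)c1cccc(NC(=O)NC(=O)CCl)c1` is the next member. It differs from compound 3 by methyl in place of hydrogen on an oxygen on a saturated carbon. Among the measured compounds shown here, no measured pair shows a hydroxy going to a methoxy, so the measured steps only say that the substituent at this chain carbon has so far mattered little, as seen from compound 2 to compound 3. Compound 4 is therefore expected to give about 5000 nM in this assay, within 2000 nM to 15000 nM. The step expected is a 1.1-fold higher number from compound 3 to compound 4 (0.04 log units; within the scatter), that is none beyond the scatter.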

Compound 4, half-maximal inhibitory concentration: 4200 nM
For compound 4 the middle estimate is 1.2-fold (0.08 log units) above the measured one; measured number inside the range.
By their numbers in this assay, from the lowest: compounds 2, 4 and 3 (each within the scatter of the next); then compound 1.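

In this assay capping the hydroxy as methoxy leaves the number in place (a 1.1-fold lower number from compound 3 to compound 4 (0.04 log units; within the scatter)), and methoxy in place of hydrogen on the chain carbon does the same (a 1.2-fold higher number from compound 2 to compound 4 (0.08 log units; within the scatter)), so hydrogen, hydroxy and methoxy at this carbon cannot be told apart on this read-out. Among these compounds, the first single change beyond the scatter lies elsewhere: with 1-methoxypentyl held constant, (chloromethyl)carbonyl in place of 3-chloropropyl on an amide-type nitrogen gives a large step (a 12-fold lower number from compound 1 to compound 4 (1.08 log units; beyond the scatter)), so the gap to compound 1 can now be read as one change, and in this set the number answers to that nitrogen substituent rather than to the chain carbon. No supporting evidence is available to explain the size of either kind of step.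

Going by these compounds, the size of the nitrogen step is known only with the 1-methoxypentyl group in place, so it remains open whether it holds with hydroxy or hydrogen on the chain carbon. Also open, on these data alone, is whether an amine or a carboxylic acid on that carbon, or a longer chain in place of the pentyl, would move the number beyond the scatter.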